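The source may report more compounds than this note shows. Statements on the series, on what has been measured and on what is new or still open speak of the compounds shown alone.

Working notes on the sulfonylaziridine sugar series in an ADME assay on MRC5 cells (Homo sapiens) for cytotoxicity, read by MTT assay, with a stated time of 48 h; on this read-out lower numbers stand for stronger inhibition and higher numbers for weaker inhibition.

Compound 1 `CCCC1(CO[C@@H]2O[C@@H]3CO[C@H](c4ccccc4)O[C@@H]3[C@H](OCc3ccccc3)[C@H]2OCc2ccccc2)CN1S(=O)(=O)c1ccc(C)cc1` is the propyl-bearing member. In this assay compound 1 gives 793000 nM. Of the two numbers recorded so far, compound 1 stands at the higher end. Compound 3 `Cc1ccc(S(=O)(=O)N2CC2(C)CO[C@@H]2O[C@@H]3CO[C@H](c4ccccc4)O[C@@H]3[C@H](O)[C@H]2O)cc1` gives 312000 nM in this assay, a lower number, and the gap between compound 3 and compound 1 lies beyond the scatter of repeated runs. Compound 2 `Cc1ccc(S(=O)(=O)N2C(C)C2CO[C@@H]2O[C@@H]3CO[C@H](c4ccccc4)O[C@@H]3[C@H](OCc3ccccc3)[C@H]2OCc2ccccc2)cc1` returns only a limit of this assay, > 1000000 nM. One of the three values therefore sits at the limit of > 1000000 nM in this assay, at which 1 of the 3 values shown sits.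

Compound 4 `Cc1ccc(S(=O)(=O)N2CC2(C)CO[C@@H]2O[C@@H]3CO[C@H](c4ccccc4)O[C@@H]3[C@H](OCc3ccccc3)[C@H]2OCc2ccccc2)cc1` is not yet measured. Against compound 1 the change is hydrogen in place of ethyl on a saturated chain carbon bound to a saturated ring carbon. Among the compounds with values here, no measured pair differs in this place alone, so the step has to be judged from the overall picture, in which all values stay weak and close together. No move beyond the scatter is expected from compound 1 to compound 4; the estimated step is a 1.1-fold lower number from compound 1 to compound 4 (0.05 log units; within the scatter). On that basis compound 4 is expected to give about 700000 nM in this assay, with a plausible range from 300000 nM to 1500000 nM. A result reported only as a limit, as seen with compound 2, remains a real possibility.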

Compound 4, half-maximal inhibitory concentration: > 1000000 nM
Compound 4: no number, only a limit; the forecaster's own chance of this, stated with the estimate: 35%; middle value at least 1.4-fold (0.15 log units) away from the limit.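

In this assay compound 4 returns > 1000000 nM, which is a limit of the assay and not a number. Hydrogen in place of ethyl on a saturated chain carbon bound to a saturated ring carbon gives the first single-place comparison in the series, and it reads as an at least 1.2-fold higher number from compound 1 to compound 4 (0.10 log units; that floor lies within the scatter), so only a floor is known and the full size of the step stays unknown. Cutting the same difference one bond further out, as propyl to methyl, shows no sign of a lower number at this place, and the series now gathers further at the top of the measurable range: the limit of > 1000000 nM in this assay, at which 2 of the 4 values shown sit.

The compounds shown leave open whether the number changes steadily along the chain, since a single measured value with a propyl group and a limit with a methyl group cannot define a trend. They also leave open whether a longer chain such as butyl, or an amine or a carboxylic acid at the end of the chain, would give a lower number that can be read in this assay.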